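This account rests on a few compounds, and the source may have more. Where it says the series, first, only, none or still open, it means among the compounds named here.

Measured so far:
- compound 1, `COc1cc(C(c2ccc(C)o2)c2ccc(C)o2)ccc1O`, with 44000 nM in a functional assay on RAW264.7 cells (Mus musculus) for inhibition, read by Griess assay, with a stated time of 22 h; a higher number here means a weaker inhibitor, a lower number a stronger inhibitor
- compound 2, `Cc1ccc(C(c2ccc(Cl)cc2)c2ccc(C)o2)o1`, with 50700 nM in this assay

Both numbers are weak. Compound 2 has the highest of the two values, and its nearest neighbour is compound 1, whose number is lower by an amount that lies within the usual scatter of repeated measurements, so the two cannot be told apart on these data. The two compounds also differ in more than one place, so nothing can be read from their pair about any single change.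

The next compound, compound 3, `Cc1ccc(C(c2ccc(F)cc2)c2ccc(C)o2)o1`, is the close relative of compound 2 in which the difference is fluoro in place of chloro on an aromatic carbon. Going by the values given here, there is no measured pair in this set that isolates such a swap of one halogen for another, so the size of the step has to be guessed. The expectation is that compound 3 will stay close to compound 2, with any step from compound 2 to compound 3 of a 1.2-fold higher number from compound 2 to compound 3 (0.07 log units; within the scatter) expected to lie within the scatter. For compound 3 the estimated value in this assay is 60000 nM, with a range from 25000 nM to 150000 nM.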

Compound 3, half-maximal inhibitory concentration: 44800 nM
The estimate for compound 3 lay 1.3-fold (0.13 log units) above the measured number; low and high end bracket the measured number.
By their numbers in this assay, from the lowest: compounds 1, 3 and 2 (each within the scatter of the next).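

Going by these compounds alone, compound 2 and compound 3 differ in one place, which the pair of compound 1 and compound 2 does not, so this is the first comparison that can be read as the effect of a single change. On an aromatic carbon para to a large group, fluoro in place of chloro gives a 1.1-fold lower number from compound 2 to compound 3 (0.05 log units; within the scatter) in this assay, so the two halogens cannot be told apart at this position on these data. Nothing measured here bears on this result.

From the compounds shown here alone, with only chloro and fluoro compared at this position, it remains open whether a group of another kind there, such as an amine, a nitrile or a carboxylic acid, would shift the number beyond the scatter. Also open, going by these compounds, is whether changes elsewhere on the shared core, such as a longer chain in place of a methyl group, could move these weak numbers.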